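Hydrazone series: chloro in place of methoxy at compound 4

A few compounds are considered here, and "the series" means these few. Any claim that something is new, unique, unknown or untested is made for them only; others in the source may bear on it.

compound 1, `COc1ccc(/C=N/N(C)c2ncnc3ccccc23)cc1OC`: 66%
compound 2, `COc1ccc(/C=N/N(C)C(=O)c2ccc(OC)c(OC)c2)cc1OC`: 79%
compound 3, `COc1ccc(C(=O)N(C)/N=C/c2ccc(OC)c(OC)c2)cc1`: 62%

All three numbers come from a functional assay on the whole organism (strain A/J) for inhibition, with Mus musculus as the target, with stated times of 1 h and 18 h, at a dose of 100 umol/kg by the oral route; a lower number here means less inhibition, a higher number more inhibition at the dose given (going by the name of the read-out). Compound 3 stands lowest of the three: its gap to compound 1 lies within the scatter, while the step of a number 17 percentage points lower from compound 2 to compound 3 (beyond the scatter) is beyond it and modest. Compound 4 `COc1ccc(/C=N/N(C)C(=O)c2ccc(Cl)cc2)cc1OC` differs from compound 3 by chloro in place of methoxy on an aromatic carbon. Among the compounds with values here, no measured step swaps methoxy for chloro; the one step in hand also takes a methoxy away and cost a modest amount, which serves as a rough bound. For compound 4 a small downward step or none beyond the scatter is expected in this assay, namely a number 5 percentage points lower from compound 3 to compound 4 (within the scatter). Compound 4 is therefore estimated at 57%, with a range from 40% to 74%.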

Compound 4, a percentage reported as inhibition, in the whole organism at one dose (the size of the read-out at that dose, not a potency): 72%
Beside the measured number, compound 4's estimate is 15 percentage points below it; low and high end bracket the measured number.
By their numbers in this assay, from the lowest: compounds 3, 1, 4 and 2 (each within the scatter of the next, the first and the last beyond it).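

In this assay the change from 4-methoxyphenyl to 4-chlorophenyl gives a number 10 percentage points higher from compound 3 to compound 4 (within the scatter) and so leaves the read-out unchanged within the usual variation. Within the data shown here, this is the first replacement of a methoxy by something other than hydrogen, and this position accepts chloro without a measurable loss at the dose given. Nothing on hand accounts for this result.

On these data alone, whether an amino group or a carboxylic acid at this position would hold the read-out remains open. The compounds shown also leave open how a longer alkoxy chain would behave here.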